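A few compounds are considered here, and "the series" means these few. Any claim that something is new, unique, unknown or untested is made for them only; others in the source may bear on it.

Measured compounds:
compound 1 `Cc1cc(CN(CC2CC2)C(CC(=O)O)c2ccc(Cl)cc2)ccc1OCCN1C(=O)CCC1=O` 65 nM
compound 2 `CCN(Cc1ccc(OCCn2c(=O)ccn(C)c2=O)c(C)c1)C(CC(=O)O)c1ccc(Cl)cc1` 428 nM
compound 3 `CCCN(Cc1ccc(OCCn2c(=O)ccn(C)c2=O)c(C)c1)C(CC(=O)O)c1ccc(Cl)cc1` 123 nM

In an assay on CHO cells for displacement of a labelled ligand from C-X-C chemokine receptor type 3 (Homo sapiens), with a stated time of 60 min (on this read-out lower numbers stand for stronger inhibition and higher numbers for weaker inhibition), compound 3 gives 123 nM, the second highest of the three numbers; its gap to compound 1 lies within the scatter, its gap to compound 2 beyond it. Compound 4 `Cc1cc(CN(CC2CC2)C(CC(=O)O)c2ccc(Cl)cc2)ccc1OCCn1c(=O)ccn(C)c1=O` is not yet measured. The change from compound 3 is cyclopropyl in place of ethyl on a saturated chain carbon bound to an amine nitrogen; cut one bond further out, it reads propyl to cyclopropylmethyl, on a saturated chain carbon bound to an amine nitrogen. Going by the values given here, only one measured step touches this chain: a 3.5-fold lower number from compound 2 to compound 3 (0.54 log units; beyond the scatter), a gain on adding one carbon. Compound 1 carries the same cyclopropylmethyl chain as compound 4 but another ring at the ether end, so it bears only indirectly. The expected step is a 1.5-fold lower number from compound 3 to compound 4 (0.19 log units; within the scatter), a small gain. Compound 4 is estimated at 80 nM, within 35 nM to 200 nM.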

Compound 4, half-maximal inhibitory concentration: 91 nM
Beside the measured number, compound 4's estimate is 1.1-fold (0.06 log units) below it, and the stated range covers the measured number.
By their numbers in this assay, from the lowest: compounds 1, 4 and 3 (each within the scatter of the next); then compound 2.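

In this assay, cyclopropyl in place of ethyl on a saturated chain carbon bound to an amine nitrogen gives a 1.4-fold lower number from compound 3 to compound 4 (0.13 log units; within the scatter) and so does not separate the propyl and cyclopropylmethyl chains. Cyclopropyl in place of methyl at the same place gives a 4.7-fold lower number from compound 2 to compound 4 (0.67 log units; beyond the scatter) and leaves the shorter chain of compound 2 apart from both. With cyclopropylmethyl held, exchanging the ring groups on a saturated chain carbon, two bonds along the chain from an oxygen on an aromatic ring, gives a 1.4-fold higher number from compound 1 to compound 4 (0.15 log units; within the scatter) and does not separate them. No measured evidence accounts for these steps. From the compounds shown here alone, whether a longer chain such as butyl, or a larger ring such as cyclobutylmethyl, would move the number beyond the scatter remains open.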